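A few compounds are considered here, and "the series" means these few. Any claim that something is new, unique, unknown or untested is made for them only; others in the source may bear on it.

Four compounds built on one shared core are compared here. Compound 1 `COc1ccccc1/C=c1/[nH]c(=O)/c(=C\c2ccccc2OC)n(C)c1=O` carries two methoxyphenyl arms and a methyl on one ring nitrogen; compound 2 `COc1ccccc1/C=c1/[nH]c(=O)/c(=C\c2cccc(Cl)c2Cl)[nH]c1=O` pairs a methoxyphenyl arm with a dichlorophenyl arm and has no substituent on either ring nitrogen; compound 3 `C=CCn1c(=O)/c(=C\c2cccc(Cl)c2Cl)[nH]c(=O)/c1=C\c1ccccc1OC` keeps that pairing but places an allyl on one ring nitrogen. All were tested in a functional assay on MCF7 cells (Homo sapiens) for cytotoxicity, read by CCK-8 assay, with a stated time of 72 h; on this read-out higher numbers stand for weaker inhibition and lower numbers for stronger inhibition. In this assay compound 1 gives 9000 nM. Compound 2 gives "not active" (no number reported), with no number reported. Compound 3 gives 2100 nM, the lower of the two numbers, and its gap to compound 1 lies beyond the usual scatter.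

Compound 4 `COc1ccccc1/C=c1\c(=O)[nH]/c(=C/c2cccc(Cl)c2Cl)c(=O)n1C` has not yet been measured. It differs from compound 3 by hydrogen in place of vinyl on a saturated chain carbon bound to an aromatic nitrogen, that is, allyl becomes methyl on the nitrogen. Among the compounds with values here, compound 1, the only other methyl-on-nitrogen compound, is the weaker of the two numbered compounds, though it also differs in its aryl arm, so no clean comparison exists. On that thin basis, a modest loss of potency is expected, a 1.9-fold higher number from compound 3 to compound 4 (0.28 log units; within the scatter), in this assay. Compound 4 is therefore estimated at 4000 nM, within a range from 1500 nM to 15000 nM.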

Compound 4, half-maximal inhibitory concentration: 200 nM
The estimate for compound 4 lay 20-fold (1.30 log units) above the measured number; the whole stated range lies above it.
By their numbers in this assay, from the lowest: compound 4; then compound 3; then compound 1.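

In this assay, within the data shown here, the allyl-to-methyl change on the ring nitrogen brings an 11-fold lower number from compound 3 to compound 4 (1.02 log units; beyond the scatter), so this position responds strongly to the group it carries, something the earlier compounds could not show because none of them isolated this one change. The aryl arm also counts: with the methyl kept in place, 2,3-dichlorophenyl in place of 2-methoxyphenyl brings a 45-fold lower number from compound 1 to compound 4 (1.65 log units; beyond the scatter), which separates the effect of that arm from the effect of the group on nitrogen. No measurement on hand explains either step, so the reason for these large shifts stays unknown.

As far as these compounds go, compound 2, with no substituent on either ring nitrogen, is reported without a number, so its steps to the other compounds cannot be read and the size of the effect of methyl over plain hydrogen remains unknown. Also open, from the compounds shown here alone, are how an ethyl group, a longer chain such as propyl or a chain ending in an amine or a carboxylic acid would compare with methyl on this nitrogen.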